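Positional shift of the ring bromine on the triazole aryl

A few compounds are considered here, and "the series" means these few. Any claim that something is new, unique, unknown or untested is made for them only; others in the source may bear on it.

Measured compounds:
compound 1 `CC1(C)[C@H]2CC[C@]1(C)N(Cc1cn(-c3ccccc3O)nn1)C(=O)C2`, 120 nM
compound 2 `CC1(C)[C@H]2CC[C@]1(C)N(Cc1cn(-c3ccccc3)nn1)C(=O)C2`, 90 nM
compound 3 `CC1(C)[C@H]2CC[C@]1(C)N(Cc1cn(-c3ccccc3Br)nn1)C(=O)C2`, 150 nM

In a functional assay on HepG2 cells (Homo sapiens) for inhibition, read by MTT assay, with a stated time of 24 h (a higher number here means a weaker inhibitor, a lower number a stronger inhibitor), compound 3 gives the highest of the three numbers, but all three sit within the scatter of one another: a 1.3-fold higher number from compound 1 to compound 3 (0.10 log units; within the scatter) and a 1.7-fold higher number from compound 2 to compound 3 (0.22 log units; within the scatter), and among the other pair a 1.3-fold lower number from compound 1 to compound 2 (0.12 log units; within the scatter). No word of order between them is warranted.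

Compound 4 `CC1(C)[C@H]2CC[C@]1(C)N(Cc1cn(-c3ccc(Br)cc3)nn1)C(=O)C2` is still to be measured. 4-bromophenyl in place of 2-bromophenyl on an aromatic nitrogen

Among the compounds with values here, no measured step moves a substituent from one ring carbon to another, so nothing bears directly on this change. What the series does show is that adding bromo or hydroxy, or removing them, on this ring leaves the number within the scatter, as in a 1.7-fold higher number from compound 2 to compound 3 (0.22 log units; within the scatter) and a 1.3-fold lower number from compound 1 to compound 2 (0.12 log units; within the scatter). A step within the scatter is therefore expected: a 1.2-fold lower number from compound 3 to compound 4 (0.06 log units; within the scatter). For compound 4 the expected value in this assay is 130 nM, with a range of 60 nM to 320 nM.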

Compound 4, half-maximal inhibitory concentration: 110 nM
For compound 4 the middle estimate is 1.2-fold (0.07 log units) above the measured one; the measured number falls inside the stated range.
By their numbers in this assay, from the lowest: compounds 2, 4, 1 and 3 (each within the scatter of the next).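

Working notes on the aryl on the triazole: in this assay, 4-bromophenyl in place of 2-bromophenyl gives a 1.4-fold lower number from compound 3 to compound 4 (0.13 log units; within the scatter), the first direct reading of where the bromine sits, and that shift stays within the scatter. The 4-bromophenyl group also stays within the scatter of the unsubstituted phenyl, with a 1.2-fold higher number from compound 2 to compound 4 (0.09 log units; within the scatter), and of 2-hydroxyphenyl, with a 1.1-fold lower number from compound 1 to compound 4 (0.04 log units; within the scatter), so all four compounds remain unordered. No supporting data bear on why the number stays level across these changes.

Open, as far as these compounds go, is whether this level reading would hold for an amine or a carboxylic acid on the same ring. Also open, from the compounds shown here alone, is whether replacing the aryl on the triazole nitrogen with a longer alkyl chain would give a step beyond the scatter.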